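Bringing a fluoro back in place of the methoxy

The source may report more compounds than this note shows. Statements on the series, on what has been measured and on what is new or still open speak of the compounds shown alone.

In a functional assay on KYSE-70 cells for antiproliferative activity against KYSE-70 cell line (Homo sapiens), read by MTT assay, with a stated time of 72 h (on this read-out higher numbers stand for weaker inhibition and lower numbers for stronger inhibition), compound 1 (`O=C(Nc1cccc(F)c1)c1cc(=O)[nH]c2cc(-c3ccc(F)cc3)ccc12`) gives 3300 nM. Compound 2 (`CC(=O)c1ccc(-c2ccc3c(C(=O)Nc4cccc(F)c4)cc(=O)[nH]c3c2)cc1`) reads > 20000 nM, which is a limit and not a number. Compound 3 (`COc1ccc(-c2ccc3c(C(=O)Nc4cccc(F)c4)cc(=O)[nH]c3c2)cc1`) also reads > 20000 nM, again only a limit, so its true position on the scale is not known.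

Compound 4 (`O=C(Nc1cccc(F)c1)c1cc(=O)[nH]c2cc(-c3cccc(F)c3)ccc12`) carries 3-fluorophenyl in place of 4-methoxyphenyl on an aromatic carbon. Among the compounds with values here, two measured steps bear on this change. The closer one is an at least 6.0-fold higher number from compound 1 to compound 3 (0.78 log units; beyond the scatter), with methoxy in place of fluoro, and an at least 6.0-fold higher number from compound 1 to compound 2 (0.78 log units; beyond the scatter) shows the same direction with acetyl in place of fluoro. Both lie beyond the scatter, and both count only as minimum sizes. Compound 4 restores a fluoro, so a partial reversal of the first step is expected, towards stronger inhibition. The reversal may not be exact, as the 3-fluorophenyl of compound 4 is not the aryl group of compound 1. The expected change is an at least 4.0-fold lower number from compound 3 to compound 4 (0.60 log units; beyond the scatter). For compound 4 the estimate is 5000 nM, with an expected range of 1800 nM to 18000 nM.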

Compound 4, half-maximal inhibitory concentration: 12000 nM
The estimate for compound 4 lay 2.4-fold (0.38 log units) below the measured number, within the range that was stated.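

In this assay, compound 4 shows that an aryl group at this position can carry its fluoro elsewhere than in compound 1 and still give a number rather than a limit. Against the methoxy and acetyl compounds only floors can be read, an at least 1.6-fold lower number from compound 3 to compound 4 (0.22 log units; that floor lies within the scatter) and an at least 1.6-fold lower number from compound 2 to compound 4 (0.22 log units; that floor lies within the scatter), because those two compounds stand at a limit and not at a number: the limit of > 20000 nM in this assay, at which 2 of the 4 values shown sit. The one step with a true size is a 3.6-fold higher number from compound 1 to compound 4 (0.56 log units; beyond the scatter), so 3-fluorophenyl in place of 4-fluorophenyl is itself a change that can be read at this position.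

On these data alone, how far compound 2 and compound 3 lie past their limit remains open. So does whether a chloro, an amine or a carboxylic acid on this aryl ring would give a number at all.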